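Cyano in place of ethynyl: an open step

This account rests on a few compounds, and the source may have more. Where it says the series, first, only, none or still open, it means among the compounds named here.

Among the compounds with values here, in a functional assay on HCT-116 cells (Homo sapiens) for antiproliferative activity, read by radiometric assay, with a stated time of 72 h (on this read-out lower numbers stand for stronger inhibition and higher numbers for weaker inhibition), compound 1 (`Cc1ccccc1Nc1ncnc2cc(NC(=O)CCCCCCC(=O)NO)sc12`) gives 2560 nM, while compound 2 (`C#Cc1cccc(Nc2ncnc3cc(NC(=O)CCCCCCC(=O)NO)sc23)c1`) gives 1010 nM, the lower of the only two numbers available. Within the data shown here, the single measured step is a 2.5-fold lower number from compound 1 to compound 2 (0.40 log units; beyond the scatter), and it exchanges 2-methylphenyl for 3-ethynylphenyl. Compound 3 (`N#Cc1cccc(Nc2ncnc3cc(NC(=O)CCCCCCC(=O)NO)sc23)c1`) has cyano in place of ethynyl on an aromatic carbon, meta to a large group: cyano in place of ethynyl on an aromatic carbon. Among the measured compounds shown here, no measured compound carries a cyano group, so the step to compound 2 offers only a rough scale for a change in this group. A swap that keeps the triple bond and the heavy-atom count should move the number less than that modest step did, with a slight rise as a tentative direction. The expected change is a 1.4-fold higher number from compound 2 to compound 3 (0.14 log units; within the scatter). For compound 3 the estimated value is 1400 nM, with an expected range from 550 nM to 3500 nM.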

Compound 3, half-maximal inhibitory concentration: 2090 nM
For compound 3 the middle estimate is 1.5-fold (0.17 log units) below the measured one; measured number inside the range.
By their numbers in this assay, from the lowest: compound 2; then compounds 3 and 1 (each within the scatter of the next).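

In this assay, the exchange at this aromatic carbon is not neutral, although ethynyl and cyano have the same heavy-atom count and each has a triple bond outside aromatic rings: the change gives a 2.1-fold higher number from compound 2 to compound 3 (0.32 log units; beyond the scatter). The gain seen with 3-ethynylphenyl does not carry over to 3-cyanophenyl, as the comparison with the 2-methylphenyl compound gives a 1.2-fold lower number from compound 1 to compound 3 (0.09 log units; within the scatter), leaving compound 2 with the lowest number of the three. No available evidence bears on the reason for this step.

The compounds shown leave open how a methyl group, a chlorine atom or an amine would read on the same aromatic carbon. They also leave open whether ethynyl stands apart from such groups or cyano alone falls short of it.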